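A few compounds are considered here, and "the series" means these few. Any claim that something is new, unique, unknown or untested is made for them only; others in the source may bear on it.

In an ADME assay on HEK293 cells (Homo sapiens) for inhibition, with a stated time of 72 h (on this read-out higher numbers stand for an effect only at larger amounts of compound and lower numbers for an effect already at smaller amounts), compound 1, `C=CC(=O)Nc1cccc(-c2nc3ccccc3s2)c1`, gives only the assay limit, > 25000 nM. Compound 2, `O=C(O)/C=C/C(=O)Nc1cccc(-c2nc3ccccc3s2)c1`, likewise reaches only the limit, > 25000 nM. The step that the two limits leave unreadable from compound 1 to compound 2 therefore cannot be read, as the limit of > 25000 nM in this assay, at which 2 of the 2 values shown sit, shows. Compound 3, `O=C(CCl)Nc1cccc(-c2nc3ccccc3s2)c1`, differs from compound 2 by chloromethyl in place of 2-carboxyethenyl on a carbonyl carbon. No measured step reads on this exchange, so with both shown values sitting at the limit, compound 3 is expected to stay near the same region, a step of a number no higher from compound 2 to compound 3 (the limit leaves the size open) of no readable size. Compound 3 is estimated at 25000 nM, within 8000 nM to 60000 nM.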

Compound 3, half-maximal effective concentration: 10000 nM
Compound 3: the middle estimate sits 2.5-fold (0.40 log units) above what was measured; measured number inside the range.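

In this assay, the group on this carbonyl carbon proves able to shift the read-out: chloromethyl in place of 2-carboxyethenyl gives an at least 2.5-fold lower number from compound 2 to compound 3 (0.39 log units; beyond the scatter). Chloromethyl in place of vinyl gives an at least 2.5-fold lower number from compound 1 to compound 3 (0.39 log units; beyond the scatter). Compound 3 is the only one of the three with a readable number, and the true size of both steps stays open because the other two values are limits: the limit of > 25000 nM in this assay, at which 2 of the 3 values shown sit.

On these data alone, what a methyl or bromomethyl group on this carbonyl carbon would give remains open. The shift therefore cannot yet be tied to the chlorine itself.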